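Carbamate aryl swap: methoxy to fluoro on compound 3

The source may report more compounds than this note shows. Statements on the series, on what has been measured and on what is new or still open speak of the compounds shown alone.

Compound 3 `COc1cccc(NC(=O)Oc2cc(=O)n(CCCO)c3c2CC(CC=C(C)C)C(C)(C)C3)c1` carries a (3-methoxyphenyl)carbamoyl group on the aromatic oxygen of the shared core; in a functional assay on PANC-1 cells (Homo sapiens) for inhibition, read by MTT assay, with a stated time of 24 h, tested at 10 uM (a higher number here means more inhibition at the concentration tested (going by the name of the read-out), a lower number less inhibition), compound 3 gives 0%, the lowest of the three numbers. The two prenyl-type ethers sit higher: compound 1 `CC(C)=CCOc1cc(=O)n(CCCO)c2c1CC(CC=C(C)C)C(C)(C)C2` gives 7.5% and compound 2 `CC(C)=CCC/C(C)=C/COc1cc(=O)n(CCCO)c2c1CC(CC=C(C)C)C(C)(C)C2` gives 18.4%. The steps to compound 3 read a number 7.5 percentage points lower from compound 1 to compound 3 (within the scatter) and a number 18.4 percentage points lower from compound 2 to compound 3 (beyond the scatter), so the carbamate itself is at or within the scatter of the smaller ether and somewhat under the larger one.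

Compound 4 `CC(C)=CCC1Cc2c(OC(=O)Nc3cccc(F)c3)cc(=O)n(CCCO)c2CC1(C)C` differs from compound 3 only on the aryl of the carbamate: fluoro in place of methoxy on an aromatic carbon. Among the compounds with values here, none of the measured steps touches a substituent on that aryl; all three concern the group on the aromatic oxygen as a whole. Within the data shown here, there is therefore no step to lean on, and the best reading is that compound 4 stays near compound 3. The expected step is a number 5 percentage points higher from compound 3 to compound 4 (within the scatter), an estimate that means no change beyond the scatter. For compound 4 in this assay the estimate is 5%, within 0% to 15%.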

Compound 4, a percentage reported as inhibition, at one concentration (the size of the read-out at that concentration, not a potency): 0%
Compound 4: middle estimate off by 5 percentage points, on the high side; low and high end bracket the measured number.
By their numbers in this assay, from the lowest: compounds 3, 4 and 1 (each within the scatter of the next); then compound 2.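

In this assay, within the data shown here, the change reads no change at the digits printed from compound 3 to compound 4 (within the scatter), the first reading on a substituent of the carbamate aryl: fluoro in place of methoxy on an aromatic carbon, meta to a large group, leaves the number where it was. The comparisons with the ethers repeat for the fluoro carbamate, with a number 18.4 percentage points lower from compound 2 to compound 4 (beyond the scatter) and a number 7.5 percentage points lower from compound 1 to compound 4 (within the scatter), so the gap to the larger ether holds for both carbamates, while the smaller ether stays within the scatter of both. Nothing at hand bears on the reason for this result.

From the compounds shown here alone, with compound 3 and compound 4 both at the bottom of the read-out, only a rise could register at this position, so whether an amine or a carboxylic acid on the aryl would lift the number stays open. Also open, going by these compounds, is whether a chain longer than 3,7-dimethylocta-2,6-dien-1-yl on the oxygen would go beyond compound 2.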